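Fluorophenyl Replaces Acetylphenyl on a Shared Scaffold

The compounds below may be only part of what the source reports. "The series", "measured", "known", "first", "only" and "open" are said of these compounds alone.

compound 1 `c1cn2cc(-c3ccsc3)nc(-c3ccc4ncn(C5CCCCC5)c4c3)c2n1` — 6.09%
compound 2 `CC(=O)c1ccc(-c2cn3ccnc3c(-c3ccc4ncn(C5CCCCC5)c4c3)n2)cc1` — 3.02%

Of the compounds shown here, two have been measured in a functional assay on U-251 cells (Homo sapiens) for inhibition, read by sulforhodamine B assay, with a stated time of 48 h, tested at 10 uM; a lower number here means less inhibition, a higher number more inhibition at the concentration tested (going by the name of the read-out). Compound 1 gives 6.09% and compound 2 gives 3.02%. Going by the values given here, the only measured step, a number 3.1 percentage points lower from compound 1 to compound 2 (within the scatter), lies within the scatter, so the two values cannot be ordered and neither compound counts as giving a higher or lower number than the other; compound 2 simply has the nearest measured neighbour in compound 1.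

Compound 3 `Fc1ccccc1-c1cn2ccnc2c(-c2ccc3ncn(C4CCCCC4)c3c2)n1` differs from compound 2 by 2-fluorophenyl in place of 4-acetylphenyl on an aromatic carbon. Among the compounds with values here, the single measured step bears directly on this change, since it exchanged one group at the same aromatic carbon of the shared core and produced no movement beyond the scatter. With nothing else to go on, compound 3 is expected to stay in the same region, and the estimated step of a number 2 percentage points higher from compound 2 to compound 3 (within the scatter) is expected to fall within the scatter. Compound 3 is therefore estimated at 5% in this assay, with a range from -8% to 18%.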

Compound 3, a percentage reported as inhibition, at one concentration (the size of the read-out at that concentration, not a potency): 11.4%
Beside the measured number, compound 3's estimate is 6.4 percentage points below it; measured number inside the range.
By their numbers in this assay, from the lowest: compounds 2, 1 and 3 (each within the scatter of the next).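

In this assay, putting 2-fluorophenyl on this aromatic carbon, next to the ring nitrogen, gives a number 8.4 percentage points higher from compound 2 to compound 3 (within the scatter) when it replaces 4-acetylphenyl, and a number 5.3 percentage points higher from compound 1 to compound 3 (within the scatter) when it replaces thiophen-3-yl. The earlier pair covered only thiophen-3-yl and 4-acetylphenyl, whereas these steps add a phenyl group bearing fluorine and lacking the hydrogen-bond acceptor and the double bond of 4-acetylphenyl, and the values of all three compounds still cannot be separated from one another. No supporting evidence bears on this result, so the numbers can be reported but not explained.

All the groups shown at this carbon are aromatic rings joined directly to the core, so it remains open whether an amine such as morpholine, a carboxylic acid or a longer alkyl chain there would give a step beyond the scatter. Going by these compounds, it also remains open whether 4-fluorophenyl would give a value in the same region as 2-fluorophenyl, or whether a change to the cyclohexyl group elsewhere on the scaffold would move the number more than any exchange at this carbon has.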